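This account rests on a few compounds, and the source may have more. Where it says the series, first, only, none or still open, it means among the compounds named here.

In a functional assay on MDA-MB-231 cells (Homo sapiens) for antiproliferative activity, read by MTT assay, with a stated time of 72 h (on this read-out higher numbers stand for weaker inhibition and lower numbers for stronger inhibition), compound 1 (`NC1=NC2(CCOCC2)N(OCCCOc2ccc(F)cc2)C(N)=N1`) stands without a number, since its entry reads "not determined" (no result reported) and no result was reported. In this assay compound 2 (`NC1=NC2(CCSCC2)N(OCCCOc2cccc(Cl)c2Cl)C(N)=N1`) gives 1 nM as the only figure available in this small set. Compound 3 (`NC1=NC2(CCOCC2)N(OCCCOc2cccc(Br)c2)C(N)=N1`) departs from compound 1 in one place, on an oxygen on a saturated carbon, where 3-bromophenyl stands in place of 4-fluorophenyl (3-bromophenyl in place of 4-fluorophenyl on an oxygen on a saturated carbon) and the rest of the structure is kept. Within the data shown here, with no starting value, the size of this step in this assay cannot be read from compound 1, and no measured step offers a guide. The expectation rests on compound 2 alone, at 1 nM and with a wide margin, and points to somewhat weaker inhibition than that figure. Compound 3 is estimated at 10 nM with an expected range of 1 nM to 100 nM in this measurement.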

Compound 3, half-maximal inhibitory concentration: 400 nM
The estimate for compound 3 lay 40-fold (1.60 log units) below the measured number; measured number outside the range, above it.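

In this assay, among these compounds, compound 1 carries no number, and no step from it to compound 3 can be read. The compounds shown leave open what 3-bromophenyl in place of 4-fluorophenyl does to inhibition. No evidence at hand bears on this result.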